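The compounds below may be only part of what the source reports. "The series", "measured", "known", "first", "only" and "open" are said of these compounds alone.

Measured in a functional assay on HepG2 cells (Homo sapiens) for antiproliferative activity, read by CCK-8 assay, with a stated time of 48 h; on this read-out higher numbers stand for weaker inhibition and lower numbers for stronger inhibition:
- compound 1 `COc1ccc(/C=C\c2cc(OC)c(OC)c(OC)c2)cc1OCc1ccc(CNC(C)(C)C(=O)O)cc1`: 6500 nM
- compound 2 `COc1ccc(/C=C\c2cc(OC)c(OC)c(OC)c2)cc1OCc1ccc(CN2CCCC[C@H]2C(=O)O)cc1`: > 10000 nM (a limit, not a number)
- compound 3 `COc1ccc(/C=C\c2cc(OC)c(OC)c(OC)c2)cc1OCc1ccc(CN2CC[C@H](C(=O)O)C2)cc1`: 6400 nM

Compound 3 stands level with compound 1, the only other compound with a number, as shown by a 1.0-fold lower number from compound 1 to compound 3 (0.01 log units; within the scatter). The entry for compound 2 is only a limit. The two steps that involve it, an at least 1.5-fold higher number from compound 1 to compound 2 (0.18 log units; that floor lies within the scatter) and an at least 1.5-fold lower number from compound 2 to compound 3 (0.19 log units; that floor lies within the scatter), therefore give floors only, and both floors lie within the scatter.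

The next compound is compound 4 `COc1ccc(/C=C\c2cc(OC)c(OC)c(OC)c2)cc1OCc1ccc(CN2CC[C@@H](O)C2)cc1`, with this change: 3-hydroxypyrrolidin-1-yl in place of 3-carboxypyrrolidin-1-yl on a saturated chain carbon bound to an aromatic carbon. In words, this is 3-hydroxypyrrolidin-1-yl in place of 3-carboxypyrrolidin-1-yl on a saturated chain carbon bound to an aromatic carbon.

The measured steps bear on this change only loosely. Each exchanges one carboxy-bearing group for another, and none of them removes the carboxy group, so they give no size for this change. Among the measured compounds shown here, they show only that swapping these groups has not yet moved this assay beyond the scatter. For the measured compounds named here, the direction is therefore a tentative expectation, and a lower number is favoured for the first compound without a carboxy group.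

The step expected for compound 4 is a 2.6-fold lower number from compound 3 to compound 4 (0.41 log units; beyond the scatter). The estimate for compound 4 is 2500 nM, with an expected range of 500 nM to 9000 nM.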

Compound 4, half-maximal inhibitory concentration: 6200 nM
The estimate for compound 4 lay 2.5-fold (0.39 log units) below the measured number; the measured number falls inside the stated range.
By their numbers in this assay, from the lowest: compounds 4, 3 and 1 (each within the scatter of the next). At a limit, above all of these: compound 2.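

In this assay, 3-hydroxypyrrolidin-1-yl in place of 3-carboxypyrrolidin-1-yl on a saturated chain carbon bound to an aromatic carbon gives a 1.0-fold lower number from compound 3 to compound 4 (0.01 log units; within the scatter), so the first loss of the carboxy group in this set leaves the number within the scatter. The comparison with (1-carboxy-1-methylethyl)amino at the same place reads the same way, with a 1.0-fold lower number from compound 1 to compound 4 (0.02 log units; within the scatter), and in this small set a carboxy group at this place is therefore not needed to reach the level of compounds 1 and 3. The remaining step, an at least 1.6-fold lower number from compound 2 to compound 4 (0.20 log units; that floor lies within the scatter), cannot be read as a size, as its starting entry is a limit and not a number: the limit of > 10000 nM in this assay, at which 1 of the 4 values shown sits.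

Going by these compounds, how a methyl ester or a primary amide in place of the carboxy group would read in this assay stays open, as does the effect of a morpholin-4-yl or a piperazin-1-yl in place of the pyrrolidine ring. Also open, on these data alone, is whether the opposite stereocentre in 3-hydroxypyrrolidin-1-yl, or a longer chain between the aromatic carbon and the ring nitrogen, would take the number beyond the scatter.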